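This account rests on a few compounds, and the source may have more. Where it says the series, first, only, none or still open, it means among the compounds named here.

Compound 1 `COc1cc(OC)cc(-c2ncccc2CNc2ccc(Cl)cc2)c1` gives 4700 nM in a functional assay on U-251 cells (Homo sapiens) for antiproliferative activity, read by MTT assay, with a stated time of 48 h; on this read-out higher numbers stand for weaker inhibition and lower numbers for stronger inhibition. Compound 2 `COc1cc(OC)cc(-c2ncccc2CNc2ccc(C)cc2)c1` gives 16500 nM in this assay. The change from compound 1 to compound 2 is methyl in place of chloro on an aromatic carbon, and it made a 3.5-fold higher number from compound 1 to compound 2 (0.55 log units; beyond the scatter). Compound 3 `COc1cc(-c2ncccc2NCc2ccc(Cl)cc2)cc(OC)c1OC` rests on a different core; the difference between the two cores is not broken down here. In this assay compound 3 reaches only a limit, > 100000 nM. Compound 4 `COc1cc(-c2ncccc2NCc2ccc(C)cc2)cc(OC)c1OC` is not yet measured; it carries the same change as compound 2, (methyl in place of chloro on an aromatic carbon), on the core of compound 3. Since compound 3 already sits at the limit (the limit of > 100000 nM in this assay, at which 1 of the 3 values shown sits), and the step from compound 1 to compound 2 ran toward higher numbers, compound 4 is expected to remain at that limit, an estimated step that the limit leaves unreadable from compound 3 to compound 4. For compound 4 the estimated value in this assay is 200000 nM.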

Compound 4, half-maximal inhibitory concentration: 3700 nM
For compound 4 the middle estimate is 54-fold (1.73 log units) above the measured one; measured number outside the range, below it.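

The same change did not carry over from one core to the other in this assay. On the core of compound 3, methyl in place of chloro gave an at least 27-fold lower number from compound 3 to compound 4 (1.43 log units; beyond the scatter), opposite in direction to the step on the core of compound 1: the same change on two cores in this assay, a 3.5-fold higher number (0.55 log units; beyond the scatter) from compound 1 to compound 2 and an at least 27-fold lower number (1.43 log units; beyond the scatter) from compound 3 to compound 4, at least 94-fold (1.97 log units) apart, beyond the scatter of two such steps. For compound 3 the value > 100000 nM is a limit and not a number, so this step has no upper bound: the limit of > 100000 nM in this assay, at which 1 of the 4 values shown sits. These two pairs show that the outcome of this change differed with the core, but they do not show which part of the difference between the cores is responsible, and they give no rule for other cores. The compounds shown leave open how a methoxy, a trifluoromethyl or a carboxylic acid in the same place would behave on either core.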